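A methyltetrazole in place of an oxadiazole

The source may report more compounds than this note shows. Statements on the series, on what has been measured and on what is new or still open speak of the compounds shown alone.

Two compounds have been measured so far in an ADME assay on the whole organism for pharmacokinetics, with Rattus norvegicus as the target (on this read-out higher numbers stand for wider distribution into tissues and lower numbers for narrower distribution), and these are their values:
- Compound 1 `CC1(C)CC2(CCN(C(=O)c3ccc(C[C@@H]4CC[C@H]([C@H](O)c5ccccc5)N4)cc3)CC2)C(=O)O1` gives 9.5 L/kg here
- Compound 2 `O=C(c1ccc(C[C@@H]2CC[C@H]([C@H](O)c3ccccc3)N2)cc1)N1C[C@@H]2[C@H](C1)[C@H]2c1nnco1` gives 9 L/kg here

Compound 2 stands within the usual scatter of compound 1, so the two cannot be ranked in this assay on these numbers. Compound 3 `Cn1nnc([C@H]2[C@@H]3CN(C(=O)c4ccc(C[C@@H]5CC[C@H]([C@H](O)c6ccccc6)N5)cc4)C[C@@H]32)n1` has not yet been measured. It keeps the rest of compound 2 and carries 2-methyl-2H-tetrazol-5-yl in place of 1,3,4-oxadiazol-2-yl on a saturated ring carbon of a three-membered non-aromatic ring of carbon only 2-methyl-2H-tetrazol-5-yl in place of 1,3,4-oxadiazol-2-yl on a saturated ring carbon in that place. Going by the values given here, no measured pair shows what a single change of this kind does, so the data offer no direct guide. Among the compounds with values here, the only anchors are compound 2 at 9 L/kg and compound 1 at 9.5 L/kg in the same range. The expected change a 1.1-fold lower number from compound 2 to compound 3 (0.02 log units; within the scatter) is therefore no larger than the scatter, with no firm direction. For compound 3 the estimate is 8.5 L/kg as the expected value, with an expected range from 4.5 L/kg to 15 L/kg for a single measurement.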

Compound 3, volume of distribution: 6.5 L/kg
The estimate for compound 3 lay 1.3-fold (0.12 log units) above the measured number; low and high end bracket the measured number.
By their numbers in this assay, from the lowest: compounds 3, 2 and 1 (each within the scatter of the next).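

In this assay, 2-methyl-2H-tetrazol-5-yl in place of 1,3,4-oxadiazol-2-yl on a saturated ring carbon of the three-membered ring gives a 1.4-fold lower number from compound 2 to compound 3 (0.14 log units; within the scatter), the first single-place step available for this series. This step cannot be told from the usual scatter, so the pair shows no readable effect of this change on the read-out. At this position, a five-membered aromatic ring with 4 hetero atoms and one with 3 hetero atoms, each with no net charge, therefore give numbers that cannot be ranked, and no measurement at hand speaks to what might lie behind this result.

The compounds shown leave open whether a different kind of group on this saturated ring carbon, such as a primary amine or a carboxylic acid, would produce a step beyond the scatter. They also leave open what a tetrazole without its methyl group or a simple phenyl ring would do here, and whether the 2-methyl-2H-tetrazol-5-yl change would give a similar step with other surroundings in the molecule.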